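The source may hold more compounds than are shown below. What is called first, only, known or untested is meant among the compounds shown, and "the series" means these compounds.

Three compounds share one core and differ in a single group on it. Compound 1 `Cc1cc(-c2cnn3c(NCC4CCOCC4)nc(NC4CCOCC4)nc23)ccc1C(=O)NC1CC1` gives 540 nM in a functional assay on MDA-MB-231 cells (Homo sapiens) for antiproliferative activity; on this read-out higher numbers stand for weaker inhibition of growth and lower numbers for stronger inhibition of growth. Compound 2 `Cc1cc(-c2cnn3c(NCC4CCOCC4)nc(Nc4ccccc4)nc23)ccc1C(=O)NC1CC1` gives 1200 nM in this assay, and compound 3 `Cc1cc(-c2cnn3c(NCC4CCOCC4)nc(Oc4cccc(F)c4F)nc23)ccc1C(=O)NC1CC1` gives 12 nM in this assay. Compound 3 thus stands at the lowest of the three numbers, reached by the steps of a 45-fold lower number from compound 1 to compound 3 (1.65 log units; beyond the scatter) and a 100-fold lower number from compound 2 to compound 3 (2.00 log units; beyond the scatter), both large and well beyond the scatter.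

Compound 4 `Cc1cc(-c2cnn3c(NCC4CCOCC4)nc(Nc4cccc(F)c4)nc23)ccc1C(=O)NC1CC1` is not yet measured. It differs from compound 3 by (3-fluorophenyl)amino in place of 2,3-difluorophenoxy on an aromatic carbon. Compound 2 carries an anilino group, the closest relative of the group entering compound 4, so the step of a 100-fold lower number from compound 2 to compound 3 (2.00 log units; beyond the scatter) bears most directly on this change; running it backwards points to a large rise in the number. The step of a 45-fold lower number from compound 1 to compound 3 (1.65 log units; beyond the scatter) likewise ties the 2,3-difluorophenoxy group to the low number. Within the data shown here, no measured step shows what one fluorine on the anilino ring does by itself. Compound 4 is therefore expected to show a large rise, a 42-fold higher number from compound 3 to compound 4 (1.62 log units; beyond the scatter). Compound 4 is estimated at 500 nM, with a range from 120 nM to 2000 nM.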

Compound 4, concentration for 50% growth inhibition: 16 nM
For compound 4 the middle estimate is 31-fold (1.49 log units) above the measured one; measured number outside the range, below it.
By their numbers in this assay, from the lowest: compounds 3 and 4 (each within the scatter of the next); then compound 1; then compound 2.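

At this position the linking atom does not settle the outcome, since (3-fluorophenyl)amino in place of 2,3-difluorophenoxy gives a 1.3-fold higher number from compound 3 to compound 4 (0.12 log units; within the scatter) in this assay. The large change instead comes with a single fluoro on the anilino ring, which gives a 75-fold lower number from compound 2 to compound 4 (1.88 log units; beyond the scatter). This also reverses the comparison with oxan-4-yl on the same nitrogen: phenyl gave a 2.2-fold higher number from compound 1 to compound 2 (0.35 log units; beyond the scatter), whereas 3-fluorophenyl gives a 34-fold lower number from compound 1 to compound 4 (1.53 log units; beyond the scatter).

No measurement here explains why one fluorine has so large an effect. Going by these compounds, it also remains open whether fluorine itself is required, or whether a chloro, methyl or methoxy group in its place on the anilino ring would give a similarly low number.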